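The compounds below may be only part of what the source reports. "The series", "measured", "known", "first", "only" and "open" are said of these compounds alone.

Compounds measured so far:
compound 1 `C[C@H](Nc1nc(Cl)nc(NC(C)(C)C)n1)c1ccccc1` – 3310 nM
compound 2 `CCN(c1nc(Cl)nc(N[C@H](C)c2ccccc2)n1)C(C)C` – 3550 nM
compound 3 `CCCN(CCC)c1nc(Cl)nc(N[C@@H](C)c2ccccc2)n1` – 331 nM

In an ADME assay on the whole organism for inhibition, with Oryza sativa as the target, with a stated time of 4 days (a lower number here means a stronger inhibitor, a higher number a weaker inhibitor), compound 3 has the lowest number of the three, while compound 1 and compound 2 stand close to each other and well above it. Going by the values given here, the one step that can be traced, a 10-fold lower number from compound 1 to compound 3 (1.00 log units; beyond the scatter), came with dipropylamino in place of (tert-butyl)amino on an aromatic carbon. Compound 4 `CCCN(C)c1nc(Cl)nc(N[C@@H](C)c2ccccc2)n1` is to be measured in this assay next. It differs from compound 3 by hydrogen in place of ethyl on a saturated chain carbon bound to a nitrogen on an aromatic ring.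

Among the compounds with values here, only the step from compound 1 to compound 3 bears on this change, and it is indirect: it shows that the group on that nitrogen matters in this assay, and that the larger dipropylamino gave the lower number. Compound 4 carries the smaller methyl(propyl)amino, so a movement back toward the numbers of compound 1 and compound 2 is expected, though less than the full distance. The estimate for compound 4 is therefore 1600 nM, within 500 nM to 5000 nM, a step of a 4.8-fold higher number from compound 3 to compound 4 (0.68 log units; beyond the scatter).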

Compound 4, half-maximal inhibitory concentration: 5500 nM
The estimate for compound 4 lay 3.4-fold (0.54 log units) below the measured number, outside the stated range (above it).
By their numbers in this assay, from the lowest: compound 3; then compounds 1, 2 and 4 (each within the scatter of the next).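

In this assay this change tests the position directly: removing only the ethyl from a saturated chain carbon bound to a nitrogen on an aromatic ring, so that dipropylamino becomes methyl(propyl)amino, gave a 17-fold higher number from compound 3 to compound 4 (1.22 log units; beyond the scatter) and so the low number of compound 3 is lost with this one change. The shorter group does not take an intermediate place, since a 1.7-fold higher number from compound 1 to compound 4 (0.22 log units; within the scatter) leaves methyl(propyl)amino and (tert-butyl)amino indistinguishable in this assay. Nothing measured on these compounds accounts for the size of this step.

As far as these compounds go, it remains open whether ethyl(propyl)amino would keep part of the number of compound 3, or whether dibutylamino would extend the trend. From the compounds shown here alone, the effect of a ring amine such as piperidine at this place also remains open.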